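Sulfonamide aryl methyl removal in the benzylamide series

This account rests on a few compounds, and the source may have more. Where it says the series, first, only, none or still open, it means among the compounds named here.

Measured so far:
- Compound 1, `COc1ccc(C(=O)NCc2ccc(CNS(=O)(=O)c3ccc(C)cc3)cc2)cc1`: in an assay on MDA-MB-231 cells for binding affinity to C-X-C chemokine receptor type 4 (Homo sapiens), read by immunofluorescence and microscopy, with stated times of 10 min and 30 min (on this read-out lower numbers stand for an effect already at smaller amounts and higher numbers for an effect only at larger amounts of compound), compound 1 gives 100 nM.
- Compound 2, `Cc1ccc(S(=O)(=O)NCc2ccc(CNC(=O)c3cccc(Cl)c3)cc2)cc1`: in this assay compound 2 gives 100 nM.

Compound 2 stands level with compound 1; the step of no change at the digits printed from compound 1 to compound 2 (within the scatter) lies within the scatter, so exchanging the group on the carbonyl carbon left the read-out unchanged.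

Compound 3, `O=C(NCc1ccc(CNS(=O)(=O)c2ccccc2)cc1)c1cccc(Cl)c1`, is not yet measured. It differs from compound 2 by hydrogen in place of methyl on an aromatic carbon, a change on the sulfonyl side of the shared core rather than on the carbonyl side. Among the measured compounds shown here, no measured step touches that side, so the only precedent is the unchanged step from compound 1 to compound 2, which suggests the read-out tolerates small changes at the outer aryl groups. A step of no size beyond the scatter is therefore expected in this assay, namely a 1.3-fold higher number from compound 2 to compound 3 (0.11 log units; within the scatter). Compound 3 is estimated at 130 nM, with a range from 50 nM to 400 nM.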

Compound 3, effective concentration (reported as EC, without a stated level of effect): 1000 nM
The estimate for compound 3 lay 7.7-fold (0.89 log units) below the measured number; measured number above the stated range.
By their numbers in this assay, from the lowest: compounds 1 and 2 (each within the scatter of the next); then compound 3.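

In this assay, among the compounds shown here, the methyl on the sulfonyl side counts: the change from 4-methylphenyl to phenyl gives a 10-fold higher number from compound 2 to compound 3 (1.00 log units; beyond the scatter), the first step beyond the scatter. The outer aryl groups therefore do not behave alike, since the exchange on the carbonyl side gave no change at the digits printed from compound 1 to compound 2 (within the scatter), while the loss of a single carbon on the sulfonyl side raised the number clearly. Nothing available explains why this one methyl matters.

As far as these compounds go, it remains open whether the methyl is specifically needed on this aromatic carbon, or whether ethyl, methoxy or chlorine there would keep the number of compound 2. Also open, from the compounds shown here alone, is whether the same step appears with 4-methoxyphenyl on the carbonyl carbon, as the step has been read only with 3-chlorophenyl.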